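This account rests on a few compounds, and the source may have more. Where it says the series, first, only, none or still open, it means among the compounds named here.

Compound 1 `CNC(=O)c1cccc(Cn2nc(C)c(NC(=O)c3ccc(COc4ccccc4)cc3)c2C)c1` was tested in a functional assay on MIA PaCa-2 cells (Homo sapiens) for antiproliferative activity, read by MTT assay, with a stated time of 72 h (on this read-out lower numbers stand for an effect already at smaller amounts and higher numbers for an effect only at larger amounts of compound), where compound 1 gives 6200 nM. Compound 2 `Cc1nn(Cc2cccc(C(=O)NC(C)C)c2)c(C)c1NC(=O)c1ccc(COc2ccccc2)cc1` gives 8900 nM in this assay, and the step of a 1.4-fold higher number from compound 1 to compound 2 (0.16 log units; within the scatter) lies within the scatter, so the two numbers cannot be ranked. Compound 3 `CNC(=O)c1cccc(Cn2nc(C)c(NC(=O)c3ccc(COc4cccc(OC)c4)cc3)c2C)c1` differs from compound 1 by methoxy in place of hydrogen on an aromatic carbon. Among the measured compounds shown here, the single measured step, from compound 1 to compound 2, concerns the amide-type nitrogen and not the aromatic ring, so no measured step bears on this change. Compound 3 is therefore expected to show a 1.0-fold lower number from compound 1 to compound 3 (0.01 log units; within the scatter), no shift beyond the scatter, with an estimate of 6000 nM in this assay, ranging from 2500 nM to 15000 nM.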

Compound 3, half-maximal effective concentration: 6200 nM
Estimate against measurement, compound 3: 1.0-fold (0.01 log units) below, within the range that was stated.
By their numbers in this assay, from the lowest: compounds 1, 3 and 2 (each within the scatter of the next).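

With methoxy in place of hydrogen on an aromatic carbon, the step in this assay reads no change at the digits printed from compound 1 to compound 3 (within the scatter). Among the compounds shown here, the earlier compounds varied only the amide-type nitrogen, so this is the first sign that the phenoxy part of compound 1 can carry an added methoxy group, at this one carbon, without a shift beyond the scatter. No measured evidence explains this result.

Methoxy is the only group shown here, so an amine, a carboxylic acid or a longer chain such as butoxy at this carbon remains open. Methoxy on the other carbons of this ring also remains open.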